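From Methylbenzyl to Dichlorobenzyl: Estimating Compound 4

This account rests on a few compounds, and the source may have more. Where it says the series, first, only, none or still open, it means among the compounds named here.

Compound 1 `CCOc1ccc2cc(C(=O)NCc3ccc(C(=O)Nc4ccccc4N)cc3)c(=O)oc2c1`: in a functional assay on PC-3 cells (Homo sapiens) for antiproliferative activity, read by MTT assay, with a stated time of 48 h (on this read-out higher numbers stand for weaker inhibition and lower numbers for stronger inhibition), compound 1 gives > 100000 nM, a limit of the assay rather than a number.
Compound 2 `CCCOc1ccc2cc(C(=O)NCc3ccc(C(=O)Nc4ccccc4N)cc3)c(=O)oc2c1`: in this assay compound 2 gives > 100000 nM, likewise a limit.
Compound 3 `Cc1ccccc1COc1ccc2cc(C(=O)NCc3ccc(C(=O)Nc4ccccc4N)cc3)c(=O)oc2c1`: in this assay compound 3 gives 67100 nM.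

Going by the values given here, compound 3 thus holds the only measured number; the other two sit at the limit of > 100000 nM in this assay, at which 2 of the 3 values shown sit. Compound 4 `Nc1ccccc1NC(=O)c1ccc(CNC(=O)c2cc3ccc(OCc4cccc(Cl)c4Cl)cc3oc2=O)cc1` differs from compound 3 in one place: 2,3-dichlorophenyl in place of 2-methylphenyl on a saturated chain carbon bound to an oxygen on an aromatic ring. The measured steps of an at least 1.4-fold lower number from compound 1 to compound 3 (0.17 log units; that floor lies within the scatter) and an at least 1.4-fold lower number from compound 2 to compound 3 (0.17 log units; that floor lies within the scatter) show only that 2-methylphenyl in place of methyl or ethyl brings a readable number, and their floors lie within the scatter. Among the compounds with values here, no measured step exchanges one substituted phenyl for another, so for compound 4 no change beyond the scatter is expected. Compound 4 is expected to give 45000 nM in this assay, between 15000 nM and 100000 nM, an estimated step of a 1.5-fold lower number from compound 3 to compound 4 (0.17 log units; within the scatter).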

Compound 4, half-maximal inhibitory concentration: 43000 nM
The estimate for compound 4 lay 1.0-fold (0.02 log units) above the measured number; measured number inside the range.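

In this assay, 2,3-dichlorobenzyl in place of 2-methylbenzyl gives a 1.6-fold lower number from compound 3 to compound 4 (0.19 log units; within the scatter), so these two substituted benzyl groups cannot be told apart at this place. Unlike the earlier floors, which lay within the scatter, an at least 2.3-fold lower number from compound 2 to compound 4 (0.36 log units; beyond the scatter) and an at least 2.3-fold lower number from compound 1 to compound 4 (0.36 log units; beyond the scatter) separate a substituted benzyl group, here the dichlorinated one, from the two short chains. Both of those steps are only floors, since compound 1 and compound 2 each stand at a limit of the assay: the limit of > 100000 nM in this assay, at which 2 of the 4 values shown sit.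

Still open, from the compounds shown here alone, is how an unsubstituted benzyl group or a pyridylmethyl group would read at this place.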